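Swapping the sulfonamide aryl group on a thione core

A few compounds are considered here, and "the series" means these few. Any claim that something is new, unique, unknown or untested is made for them only; others in the source may bear on it.

Measured compounds:
- compound 1, `Nc1ncnc2c1c(-c1ccccc1)cn2-c1ccc(S(=O)(=O)Nc2ccccn2)cc1`, 6340 nM
- compound 2, `N#Cc1c(-c2ccccc2)cn(-c2ccc(S(=O)(=O)Nc3nccs3)cc2)c1NC(=O)CCC(=O)O`, 9120 nM
- compound 3, `Nc1nc(=S)[nH]c2c1c(-c1ccccc1)cn2-c1ccc(S(=O)(=O)Nc2nccs2)cc1`, 3120 nM

Of the compounds shown here, three have been tested in a functional assay on MCF7 cells (Homo sapiens) for inhibition, read by sulforhodamine B assay, with a stated time of 24 h; a higher number here means a weaker inhibitor, a lower number a stronger inhibitor. Compound 3 gives the lowest of the three numbers, with 3120 nM. Compound 1 is its nearest neighbour, and compound 1 gives 6340 nM, a gap that lies beyond the scatter. Compound 2 stands furthest away, and compound 2 gives 9120 nM, also beyond the scatter.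

The next compound, compound 4, `Nc1nc(=S)[nH]c2c1c(-c1ccccc1)cn2-c1ccc(S(=O)(=O)Nc2ccccn2)cc1`, keeps the core of compound 3 and changes only the group on the sulfonamide nitrogen: pyridin-2-yl in place of 1,3-thiazol-2-yl on a sulfonamide nitrogen. Among the compounds with values here, no pair of measured compounds differs by this change alone, so its effect has not been observed here. Compound 1 carries the pyridin-2-yl group but on a different core, and compound 3 carries the thiazolyl group, so those two values cannot be read as a step for this change on its own.

Within the data shown here, with no direct precedent, compound 4 is expected to stay close to compound 3, with a step of a 1.4-fold higher number from compound 3 to compound 4 (0.16 log units; within the scatter) in this assay, not clearly beyond the scatter in either direction. Compound 4 is therefore estimated at 4500 nM, within a range from 2000 nM to 10000 nM.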

Compound 4, half-maximal inhibitory concentration: 3800 nM
Compound 4: the middle estimate sits 1.2-fold (0.07 log units) above what was measured; the range from low to high includes it.
By their numbers in this assay, from the lowest: compounds 3, 4, 1 and 2 (each within the scatter of the next, the first and the last beyond it).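

On the core of compound 3, pyridin-2-yl in place of 1,3-thiazol-2-yl on a sulfonamide nitrogen gives a 1.2-fold higher number from compound 3 to compound 4 (0.09 log units; within the scatter) in this assay, the first direct reading of this change among the compounds shown. The earlier compounds shown here could not supply this reading, since none of them differed by this change alone. On this core, then, a six-membered aromatic ring with one hetero atom and a five-membered aromatic ring with two hetero atoms give numbers that cannot be told apart in this assay, and nothing shown bears on why that is so.

The comparison rests on a single pair on a single core, so it remains open whether the 1,3-thiazol-2-yl group would also match pyridin-2-yl on the core of compound 1, where only the pyridin-2-yl form is shown. Also open, going by these compounds, is how far this tolerance extends on the sulfonamide nitrogen, for example to a plain phenyl ring, a pyrimidin-2-yl ring or a small methyl group, and whether a carbonyl in place of the thione would leave the numbers where they are.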